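Methyl to trifluoromethyl on the aryl amide of compound 3

The source may report more compounds than this note shows. Statements on the series, on what has been measured and on what is new or still open speak of the compounds shown alone.

Compound 1 `CN(C)C(=O)c1cc2cnc(Nc3ccc(NC(=O)C4(C(=O)Nc5cccc(F)c5)CC4)cc3)nc2n1C1CCCC1`: 33.2%
Compound 2 `CN(C)C(=O)c1cc2cnc(Nc3ccc(NC(=O)C4(C(=O)Nc5ccc(Cl)c(C(F)(F)F)c5)CC4)cc3)nc2n1C1CCCC1`: 1.1%
Compound 3 `Cc1ccc(NC(=O)C2(C(=O)Nc3ccc(Nc4ncc5cc(C(=O)N(C)C)n(C6CCCC6)c5n4)cc3)CC2)cc1`: 40.2%

These values come from a functional assay on A549 cells (Homo sapiens) for inhibition, read by CCK-8 assay, with a stated time of 72 h, tested at 1 uM; on this read-out higher numbers stand for more inhibition of growth at the one concentration tested and lower numbers for less inhibition of growth. Compound 3 stands at the upper end of this small set: the nearest comparison is a number 7 percentage points higher from compound 1 to compound 3 (within the scatter), and the furthest is a number 39.1 percentage points higher from compound 2 to compound 3 (beyond the scatter).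

Compound 4 `CN(C)C(=O)c1cc2cnc(Nc3ccc(NC(=O)C4(C(=O)Nc5ccc(C(F)(F)F)cc5)CC4)cc3)nc2n1C1CCCC1` differs from compound 3 by trifluoromethyl in place of methyl on an aromatic carbon. For the measured compounds named here, the only measured step to a trifluoromethyl-bearing ring is large, a number 32.1 percentage points lower from compound 1 to compound 2 (beyond the scatter), but the 4-chloro-3-(trifluoromethyl)phenyl of compound 2 also carries chlorine. A smaller fall, probably beyond the scatter, is therefore expected. The expected step is a number 20.2 percentage points lower from compound 3 to compound 4 (beyond the scatter). Compound 4 is estimated at 20%, with an expected range of 4% to 38%.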

Compound 4, percent growth inhibition at one concentration: -25.3%
Beside the measured number, compound 4's estimate is 45.3 percentage points above it, and the stated range ends above it.
By their numbers in this assay, from the lowest: compound 4; then compound 2; then compounds 1 and 3 (each within the scatter of the next).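

In this assay there is a number 65.5 percentage points lower from compound 3 to compound 4 (beyond the scatter) on a single change to the ring, with no chlorine involved. Against the other two aryl amides there is likewise a number 58.5 percentage points lower from compound 1 to compound 4 (beyond the scatter) and a number 26.4 percentage points lower from compound 2 to compound 4 (beyond the scatter) on this read-out, so the chlorine of compound 2 is not needed for a low number, and the 4-(trifluoromethyl)phenyl of compound 4 gives the lowest value of the set. Nothing measured here accounts for this drop.

Going by these compounds, whether a methoxy group, a nitrile or an amine on this aromatic carbon would stay near compound 3 remains open. So does how compound 4 behaves at concentrations other than the one tested.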